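This account rests on a few compounds, and the source may have more. Where it says the series, first, only, none or still open, it means among the compounds named here.

In an assay on isolated protein for displacement of a labelled ligand from Apoptosis regulator Bcl-2 (Homo sapiens), with a stated time of 15 min (on this read-out lower numbers stand for stronger inhibition and higher numbers for weaker inhibition), three compounds with a shared core have been measured, differing only in the chain attached to an oxygen on an aromatic ring. Compound 1 `CN(C)CCCNc1ccc(S(=O)(=O)NC(=O)c2ccc(N3CCN(CC4=C(c5ccc(C(F)(F)F)cc5)CC(C)(C)CC4)CC3)cc2Oc2cnc3[nH]ccc3c2)cc1[N+](=O)[O-]` gives 0.89 nM, compound 2 `CC1(C)CCC(CN2CCN(c3ccc(C(=O)NS(=O)(=O)c4ccc(OCC5CCCOC5)c([N+](=O)[O-])c4)c(Oc4cnc5[nH]ccc5c4)c3)CC2)=C(c2ccc(C(F)(F)F)cc2)C1` gives 3 nM, and compound 3 `CC1(C)CCC(CN2CCN(c3ccc(C(=O)NS(=O)(=O)c4ccc(OCC5CCSCC5)c([N+](=O)[O-])c4)c(Oc4cnc5[nH]ccc5c4)c3)CC2)=C(c2ccc(C(F)(F)F)cc2)C1` gives 1.65 nM. On these numbers compound 3 stands second highest of three, and its gaps to both others lie within the scatter: a 1.8-fold lower number from compound 2 to compound 3 (0.26 log units; within the scatter), and a 1.9-fold higher number from compound 1 to compound 3 (0.27 log units; within the scatter). Among the compounds with values here, the only step beyond the scatter is a 3.4-fold higher number from compound 1 to compound 2 (0.53 log units; beyond the scatter). Compound 4 `CC(Oc1ccc(S(=O)(=O)NC(=O)c2ccc(N3CCN(CC4=C(c5ccc(C(F)(F)F)cc5)CC(C)(C)CC4)CC3)cc2Oc2cnc3[nH]ccc3c2)cc1[N+](=O)[O-])C1CCOCC1` differs from compound 3 by 1-(oxan-4-yl)ethyl in place of (thian-4-yl)methyl on an oxygen on an aromatic ring. Within the data shown here, the step from compound 2 to compound 3 bears most directly on this change, because a 1.8-fold lower number from compound 2 to compound 3 (0.26 log units; within the scatter) also exchanged a sulfur-containing ring for an oxygen-containing ring and stayed within the scatter; the extra methyl of the entering group has no measured counterpart. Only a small change is therefore expected, estimated as a 1.5-fold higher number from compound 3 to compound 4 (0.18 log units; within the scatter). Compound 4 is expected to give 2.5 nM in this assay, with a range from 1 nM to 7 nM.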

Compound 4, half-maximal inhibitory concentration: 9.2 nM
Compound 4: middle estimate off by 3.7-fold (0.57 log units), on the low side; the measured number lies above the stated range.
By their numbers in this assay, from the lowest: compounds 1, 3 and 2 (each within the scatter of the next, the first and the last beyond it); then compound 4.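

Until now, swapping one ring-bearing chain for another at this place had stayed within the scatter, but in this assay putting 1-(oxan-4-yl)ethyl in place of (thian-4-yl)methyl gives a 5.6-fold higher number from compound 3 to compound 4 (0.75 log units; beyond the scatter) and so shows that this oxygen substituent can matter. The same chain in place of (oxan-3-yl)methyl gives a 3.1-fold higher number from compound 2 to compound 4 (0.49 log units; beyond the scatter) as a smaller but still real loss, and against the chain of compound 1 the change reaches a 10-fold higher number from compound 1 to compound 4 (1.01 log units; beyond the scatter) and leaves compound 4 the weakest of the set. No measurement shown here explains this loss.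

Going by these compounds, the step from compound 3 changes both the ring atom and the branching methyl, so the share of each remains open. A (oxan-4-yl)methyl chain, which differs from the chain of compound 4 only by that methyl, would separate the two.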